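Cytotoxicity notes on the shared core: step to compound 4

The source may hold more compounds than are shown below. What is called first, only, known or untested is meant among the compounds shown, and "the series" means these compounds.

Measured so far in an ADME assay on MT4 cells (Homo sapiens) for cytotoxicity, read by MTT assay, with a stated time of 4 days; on this read-out higher numbers stand for lower toxicity in this test and lower numbers for higher toxicity in this test:
compound 1, `CCOC(=O)c1cnc(N2CCN(Cc3cccc(C#N)c3)CC2)nc1Oc1c(C)cc(-c2ccc(C#N)cc2)cc1C`: > 125000 nM
compound 2, `CCOC(=O)c1cnc(N2CCN(Cc3ccccc3C#N)CC2)nc1Oc1c(C)cc(-c2ccc(C#N)cc2)cc1C`: > 125000 nM
compound 3, `CCOC(=O)c1cnc(N2CCN(Cc3cccc(F)c3)CC2)nc1Oc1c(C)cc(-c2ccc(C#N)cc2)cc1C`: > 125000 nM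

Compound 1 stands at a limit of this assay and not at a number. The same holds for compound 2, whose value is also a limit. Compound 3 likewise gives only a limit. All three therefore sit together at the limit of > 125000 nM in this assay, at which 3 of the 3 values shown sit, and none of the three pairwise steps can be sized: a step that the two limits leave unreadable from compound 1 to compound 2, a step that the two limits leave unreadable from compound 1 to compound 3 and a step that the two limits leave unreadable from compound 2 to compound 3 are all unreadable between two limits.

The next step changes the group on the saturated chain carbon bound to an amine nitrogen in a ring: 4-(methoxycarbonyl)phenyl in place of 3-cyanophenyl on a saturated chain carbon bound to an amine nitrogen in a ring, giving compound 4, `CCOC(=O)c1cnc(N2CCN(Cc3ccc(C(=O)OC)cc3)CC2)nc1Oc1c(C)cc(-c2ccc(C#N)cc2)cc1C`. Going by the values given here, the measured steps that bear on it are those varying that same benzylic group, from compound 1 to compound 2 and from compound 2 to compound 3, and both ended at the limit; no measured compound carries a methoxycarbonyl, so its effect in this assay has no direct precedent here. Compound 4 is therefore expected to remain at the limit as well, with a step that the limit leaves unreadable from compound 1 to compound 4 as the expected step. The estimate for compound 4 is 150000 nM, with a range from 60000 nM to 400000 nM.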

Compound 4, half-maximal cytotoxic concentration: > 125000 nM
Compound 4: a limit, no number; the forecaster's own chance of this, stated with the estimate: 85%; the middle value is on the limit's open side.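

In this assay compound 4 gives only a limit, > 125000 nM, so no step between compound 4 and compound 1, compound 2 or compound 3 can be read, and all four sit together: the limit of > 125000 nM in this assay, at which 4 of the 4 values shown sit.

The compounds shown leave open which group on the saturated chain carbon bound to an amine nitrogen in a ring, if any, would give a measured number in this assay rather than a limit.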